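Swapping Isopropylamino for Piperidin-1-yl on a Carbonyl Carbon

The source may hold more compounds than are shown below. What is called first, only, known or untested is meant among the compounds shown, and "the series" means these compounds.

In an in vitro ADME assay on microsomes from liver (Homo sapiens) for pharmacokinetics, read by LC-MS, with a stated time of 10 min, tested at 1 uM (on this read-out higher numbers stand for fast clearance and lower numbers for slow clearance), compound 2 `CC(C)NC(=O)[C@H]1CN(C)C[C@@H]1c1ccc(/C=C/C(=O)Nc2ccccc2N)cc1` gives 8 mL/min/kg, and compound 1 `CN1C[C@H](C(=O)Nc2ccc(Cl)cn2)[C@@H](c2ccc(/C=C/C(=O)Nc3ccccc3N)cc2)C1` gives 13 mL/min/kg. Among the measured compounds shown here, these are the only two numbers so far, and they lie within the scatter of each other, so compound 2 cannot be told apart from compound 1. The next structure, compound 3 `CN1C[C@H](C(=O)N2CCCCC2)[C@@H](c2ccc(/C=C/C(=O)Nc3ccccc3N)cc2)C1`, has not yet been measured. It carries piperidin-1-yl in place of isopropylamino on a carbonyl carbon, and its other neighbour there is a saturated ring carbon: piperidin-1-yl in place of isopropylamino on a carbonyl carbon.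

For the measured compounds named here, only one measured step bears on this change, a 1.6-fold lower number from compound 1 to compound 2 (0.21 log units; within the scatter). That step put isopropyl in place of 5-chloropyridin-2-yl on an amide-type nitrogen, and it stayed within the scatter. Going by the values given here, it is a different change, though, and no measured compound yet carries piperidin-1-yl, so it offers only weak guidance. A shift beyond the scatter is therefore not expected in this assay. The estimated change is a 1.4-fold higher number from compound 2 to compound 3 (0.14 log units; within the scatter). For compound 3 the expected clearance is 11 mL/min/kg, with an estimated range from 6 mL/min/kg to 21 mL/min/kg.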

Compound 3, clearance: 9 mL/min/kg
Beside the measured number, compound 3's estimate is 1.2-fold (0.09 log units) above it, and the stated range covers the measured number.
By their numbers in this assay, from the lowest: compounds 2, 3 and 1 (each within the scatter of the next).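

In this assay the carbonyl carbon has now carried three different groups, and the newest one gives a 1.1-fold higher number from compound 2 to compound 3 (0.05 log units; within the scatter) while setting it against the chloropyridine amide gives a 1.4-fold lower number from compound 1 to compound 3 (0.16 log units; within the scatter) for the same position. Among the compounds shown here, this is the first look at a ring nitrogen on that carbonyl carbon: compound 1 and compound 2 both keep the amide hydrogen, compound 3 has no such hydrogen, and the piperidin-1-yl ring brings more heavy atoms than isopropylamino, yet all three numbers remain within the scatter of one another. Among these three compounds, then, neither the loss of that hydrogen nor the added ring separates the clearance readings, and no supporting data are available to explain why they sit so close together.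

Going by these compounds, whether this holds for other groups on the same carbonyl carbon remains open, for example morpholin-4-yl, dimethylamino or a carboxylic acid in place of the amide. These numbers also cannot show whether any real difference smaller than the scatter lies among compound 1, compound 2 and compound 3.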